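A few compounds are considered here, and "the series" means these few. Any claim that something is new, unique, unknown or untested is made for them only; others in the source may bear on it.

Measured so far in a functional assay on HepG2 cells (Homo sapiens) for antiproliferative activity, read by CCK-8 assay, with a stated time of 72 h, tested at 2 uM; on this read-out lower numbers stand for a weaker effect and higher numbers for a stronger effect at the one concentration tested:

Compound 1 `CN1CCN(c2nc(Cl)nc3c2ncn3Cc2ccc(C(=O)Nc3ccccc3N)cc2)CC1` gives 60.4% in this assay.
Compound 2 `Nc1ccccc1NC(=O)/C=C/c1ccc(Cn2cnc3c(Nc4cccc(Cl)c4)nc(Cl)nc32)cc1` gives 35.8% in this assay.

Compound 2 stands lower of the two, with compound 1 above it by a gap beyond the usual scatter. Compound 3 `Nc1ccccc1NC(=O)/C=C/c1ccc(Cn2cnc3c(Nc4ccccc4)nc(Cl)nc32)cc1` differs from compound 2 in one place: hydrogen in place of chloro on an aromatic carbon. No such change has been measured here, so the step from compound 2 to compound 3 is expected to be small, most likely within the scatter and, if anything, toward a weaker effect a number 5.8 percentage points lower from compound 2 to compound 3 (within the scatter). Compound 3 is therefore estimated at 30%, with a range from 15% to 48%.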

Compound 3, a percentage reported as inhibition, at one concentration (the size of the read-out at that concentration, not a potency): 16.4%
Compound 3: the middle estimate sits 13.6 percentage points above what was measured; the range from low to high includes it.
By their numbers in this assay, from the lowest: compound 3; then compound 2; then compound 1.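

In this assay, the change from 3-chlorophenyl to phenyl gives a number 19.4 percentage points lower from compound 2 to compound 3 (beyond the scatter) and so shows that this one chlorine atom on the aromatic ring matters for the effect at the concentration tested. Going by these compounds alone, this is the first step measured at this position, and it rests on a single pair of compounds. No available evidence explains why the effect falls when the chloro leaves.

As far as these compounds go, it remains open whether fluoro, methyl or methoxy in the same place would match the chloro, fall short of it or exceed it.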